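The compounds below may be only part of what the source reports. "The series", "measured", "known", "first", "only" and "open" are said of these compounds alone.

Measured so far:

- compound 1, `C/C=C/C(=O)N(Cc1ccc(OC)c([N+](=O)[O-])c1)c1cc(OC)c(OC)c(OC)c1`: 590 nM
- compound 2, `COc1ccc(CN(C(=O)CN=[N+]=[N-])c2cc(OC)c(OC)c(OC)c2)cc1O`: 120 nM
- compound 3, `COc1ccc(N(Cc2cc(OC)c(OC)c(OC)c2)C(=O)CN=[N+]=[N-])cc1O`: 22400 nM

In a functional assay on MGC-803 cells (Homo sapiens) for inhibition, read by MTT assay, with a stated time of 48 h (a higher number here means a weaker inhibitor, a lower number a stronger inhibitor), compound 2 gives the lowest number of the three and is the most potent, since its gaps to compound 1 and to compound 3 both lie beyond the scatter. Compound 4, `COc1ccc(CN(C(=O)C(C)C)c2cc(OC)c(OC)c(OC)c2)cc1O`, is not yet measured in this assay. It differs from compound 2 by isopropyl in place of azidomethyl on a carbonyl carbon. Among the compounds with values here, the acyl group on the amide-type nitrogen is the only change, and compound 1 with its crotonyl amide already gives a higher number than compound 2, so a loss of potency of moderate size is expected rather than none. The expected step is a 3.8-fold higher number from compound 2 to compound 4 (0.57 log units; beyond the scatter). Compound 4 is estimated at 450 nM, with a range from 120 nM to 2000 nM.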

Compound 4, half-maximal inhibitory concentration: 210 nM
Beside the measured number, compound 4's estimate is 2.1-fold (0.33 log units) above it, within the range that was stated.
By their numbers in this assay, from the lowest: compounds 2 and 4 (each within the scatter of the next); then compound 1; then compound 3.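

In this assay, isopropyl in place of azidomethyl on a carbonyl carbon gives a 1.8-fold higher number from compound 2 to compound 4 (0.24 log units; within the scatter). The azidomethyl group, with its three nitrogens, is therefore not required at this place to hold a number of this order, and the purely carbon isopropyl serves there as well. No supporting data on hand account for this result. Still open, from the compounds shown here alone, is whether a longer chain, an amine or a carboxylic acid on this carbonyl carbon would keep the number in this range. Compounds 1 and 3 differ from compound 2 in more than one place, so those steps cannot be read.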